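This account rests on a few compounds, and the source may have more. Where it says the series, first, only, none or still open, it means among the compounds named here.

In an ADME assay on Vero cells (Chlorocebus sabaeus) for cytotoxicity, read by MTT assay, with a stated time of 72 h (on this read-out higher numbers stand for lower toxicity in this test and lower numbers for higher toxicity in this test), compound 1 `CO/N=C1/C(=O)N(CCCn2cc(CN3CCC[C@@H]4CN(c5c(F)cc6c(=O)c(C(=O)O)cn(C7CC7)c6c5OC)C[C@@H]43)nn2)c2ccc(C)cc21` gives 8 ug/mL. Among the compounds with values here, the only other measured compound, compound 2 `CCO/N=C1/C(=O)N(CCCn2cc(CN3CCC[C@@H]4CN(c5c(F)cc6c(=O)c(C(=O)O)cn(C7CC7)c6c5OC)C[C@@H]43)nn2)c2ccc(C)cc21`, gives 4 ug/mL, so the two values lie within the scatter of each other and neither stands clearly apart. Compound 3 `CO/N=C1/C(=O)N(CCCn2cc(CN3CCC[C@@H]4CN(c5c(F)cc6c(=O)c(C(=O)O)cn(C7CC7)c6c5OC)C[C@@H]43)nn2)c2ccc(F)cc21` differs from compound 1 in one place: fluoro in place of methyl on an aromatic carbon.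

Within the data shown here, the only measured step, a 2.0-fold lower number from compound 1 to compound 2 (0.30 log units; within the scatter), is methyl in place of hydrogen on a saturated chain carbon bound to an oxygen on an unsaturated carbon. That is a different change at a different place, so it bears on the new change only indirectly, as a sign that one small exchange stayed within the scatter. Among the measured compounds shown here, no measured pair tests a change on the aromatic carbon. No step beyond the scatter is therefore expected in this assay, and the estimated step is no change at the digits printed from compound 1 to compound 3 (within the scatter). For compound 3 the expected value is 8 ug/mL, with an estimated range from 3 ug/mL to 20 ug/mL.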

Compound 3, half-maximal cytotoxic concentration: 4 ug/mL
Compound 3: middle estimate off by 2.0-fold (0.30 log units), on the high side, and the stated range covers the measured number.
By their numbers in this assay, from the lowest: compounds 2, 3 and 1 (each within the scatter of the next).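

In this assay, within the data shown here, the exchange of methyl for fluoro gives the first reading at this aromatic carbon, on the six-membered aromatic ring of carbon only, and it comes out as a 2.0-fold lower number from compound 1 to compound 3 (0.30 log units; within the scatter). The exchange swaps one heavy atom for another, with no hydrogen-bond donors or acceptors on either side, and in this test it does not set compound 3 apart from compound 1, so the two can only be read as alike here. Nothing measured here accounts for where the two numbers fall, and no such account can be offered for this exchange.

With only methyl and fluoro shown at this aromatic carbon, it remains open whether a plain hydrogen, chloro, methoxy, an amine or a carboxylic acid there would also stay within the scatter of compound 1 or would move the number clearly in either direction. From the compounds shown here alone, it also remains open whether a larger group at this place, such as a phenyl ring or a longer chain, would leave the reading in this assay as it stands.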